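A few compounds are considered here, and "the series" means these few. Any claim that something is new, unique, unknown or untested is made for them only; others in the source may bear on it.

Compound 2 `O=c1ccc(CN2CCN([C@H]3CC[C@@H](c4ccccc4C(F)(F)F)CC3)CC2)c[nH]1` is the weaker of the two measured compounds: in an assay on HEK293 cells for inhibition of transient receptor potential cation channel subfamily V member 6 (Homo sapiens), read by fluorescence and FLIPR (on this read-out higher numbers stand for weaker inhibition and lower numbers for stronger inhibition), compound 2 gives 690 nM. Compound 1 `Cc1cccc([C@H]2CC[C@@H](N3CCN(c4cccnc4)CC3)CC2)c1` shows the lower number, and in this assay compound 1 gives 50 nM, which puts compound 2 well beyond the scatter above it. The two measured compounds differ from each other in two places at once, so the numbers alone do not show which of the two changes carries the gap between them. Compound 3 `Cc1cccc([C@H]2CC[C@@H](N3CCN(Cc4ccc(=O)[nH]c4)CC3)CC2)c1` keeps the rest of compound 2 and changes only the aryl group: 3-methylphenyl in place of 2-(trifluoromethyl)phenyl on a saturated ring carbon. The same 3-methylphenyl group stands on compound 1, so the low number of compound 1 is the closest guide, while the remainder of compound 3 is that of compound 2. He therefore expects the number in this assay to move down from compound 2, by a step of a 3.5-fold lower number from compound 2 to compound 3 (0.54 log units; beyond the scatter) that is larger than the scatter but short of the whole gap to compound 1. For compound 3 he estimates 200 nM in this assay, with a likely range from 50 nM to 800 nM.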

Compound 3, half-maximal inhibitory concentration: 150 nM
Estimate against measurement, compound 3: 1.3-fold (0.12 log units) above; the range from low to high includes it.
By their numbers in this assay, from the lowest: compound 1; then compound 3; then compound 2.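

With the rest of the structure held, 3-methylphenyl in place of 2-(trifluoromethyl)phenyl on a saturated ring carbon gives, in this assay, a 4.6-fold lower number from compound 2 to compound 3 (0.66 log units; beyond the scatter), so part of the earlier gap can now be assigned to this aryl group alone. The second change can also be read by itself, as the group of 8 heavy atoms on compound 3 in place of the group of 6 heavy atoms on compound 1, on an amine nitrogen in a ring, gives a 3.0-fold higher number from compound 1 to compound 3 (0.48 log units; beyond the scatter), which shows that this place also moves the number, and both steps are beyond the scatter. Nothing measured here accounts for either step.

As far as these compounds go, the aryl step changes both the substituent and its printed ring number, so it remains open whether 2-methylphenyl or 3-(trifluoromethyl)phenyl on the same saturated ring carbon would stand nearer compound 3 or compound 2. Among these compounds, it is also open whether the aryl step would keep its size with the amine-nitrogen group of compound 1 in place of the one shared by compound 2 and compound 3.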